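Sulfur for Selenium on the Core of Compound 1

The source may hold more compounds than are shown below. What is called first, only, known or untested is meant among the compounds shown, and "the series" means these compounds.

Compound 1 `C[Se]/C(=N\C(=O)c1cccs1)NC(=O)c1cccs1` was tested in a functional assay on HT-29 cells (Homo sapiens) for cytotoxicity, read by MTT assay, with a stated time of 72 h (on this read-out higher numbers stand for weaker inhibition of growth and lower numbers for stronger inhibition of growth), where compound 1 gives > 100000 nM, which is a limit of the assay and not a number. Compound 2 `CS/C(=N\C(=O)c1cnc2ccccc2c1)NC(=O)c1cnc2ccccc2c1` gives > 100000 nM in this assay, again a limit. Compound 3 `O=C(/N=C(/NC(=O)c1cnc2ccccc2c1)[Se]Cc1ccccc1)c1cnc2ccccc2c1` gives > 100000 nM in this assay, also a limit. Compound 1 thus stands where every value in the set stands: the limit of > 100000 nM in this assay, at which 3 of the 3 values shown sit. The step that the two limits leave unreadable from compound 2 to compound 3 has both of its ends at that limit and so has no readable size.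

Compound 4 `CS/C(=N\C(=O)c1cccs1)NC(=O)c1cccs1` differs from compound 1 by a group of 2 heavy atoms (1 carbon, 1 sulfur; no ring) in place of a group of 2 heavy atoms (1 carbon, 1 selenium; no ring), on a carbon with a double bond to nitrogen. For the measured compounds named here, the only measured step at the same position, a step that the two limits leave unreadable from compound 2 to compound 3, concerns a different pair of groups on a different core and gives no size to carry over. Going by the values given here, no measured step moves any compound off the limit, so no change beyond the scatter is expected in this assay. Compound 4 is expected to give 100000 nM, with a range from 30000 nM to 300000 nM. The expected step of a number no higher from compound 1 to compound 4 (the limit leaves the size open) is estimated to be nil.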

Compound 4, concentration for total growth inhibition: > 100000 nM
Compound 4 ended at the assay's limit; the forecaster's own chance of this, stated with the estimate: 85%; the middle value sits exactly at the limit.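

The step between compound 1 and compound 4 cannot be read in this assay, as both ends are limits and not numbers: the limit of > 100000 nM in this assay, at which 4 of the 4 values shown sit.

The compounds shown leave open whether methylsulfanyl in place of the selenium group changes growth inhibition at all; none of them gives a number.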